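The compounds below may be only part of what the source reports. "The series", "measured", "known", "first", "only" and "open" are said of these compounds alone.

In a functional assay on HCT-116 cells (Homo sapiens) for antiproliferative activity, read by CellTiter-Glo, with a stated time of 72 h; a lower number here means a stronger inhibitor, a higher number a weaker inhibitor:
Compound 1 `O=C(NO)c1ccc(/C=C/c2ccnc(-c3cccc(O)c3)c2)cc1`: 1610 nM
Compound 2 `O=C(NO)c1ccc(/C=C/c2ccnc(-c3ccc(C(F)(F)F)cc3)c2)cc1`: > 10000 nM, a limit of the assay and not a number

For the measured compounds named here, compound 1 holds the only true number so far, which makes it the reference point. Compound 3 `O=C(NO)c1ccc(/C=C/c2ccnc(Br)c2)cc1` alters the core of compound 1, with bromo in place of 3-hydroxyphenyl on an aromatic carbon. Going by the values given here, no measured step covers this swap, so the expectation rests only on compound 1 at 1610 nM and is tentative. The expected step is a 2.5-fold higher number from compound 1 to compound 3 (0.40 log units; beyond the scatter), a modest weakening in this assay, a little beyond the scatter. For compound 3 the estimate is 4000 nM, with an expected range of 1200 nM to 13000 nM.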

Compound 3, half-maximal inhibitory concentration: > 10000 nM
Compound 3 ended at the assay's limit; the forecaster's own chance of this, stated with the estimate: 25%; middle value at least 2.5-fold (0.39 log units) away from the limit.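

Replacing 3-hydroxyphenyl with bromo on this aromatic carbon, next to the ring nitrogen, gives an at least 6.2-fold higher number from compound 1 to compound 3 (0.79 log units; beyond the scatter) in this assay. For the compounds shown here, for the first time, this shows that the activity of compound 1 does not survive when a single bromine atom stands in place of the whole ring. The value of compound 3, > 10000 nM, is a limit of the assay and not a number, so the full size of the loss stays unknown: the limit of > 10000 nM in this assay, at which 2 of the 3 values shown sit.

On these data alone, whether the ring alone or its hydroxyl matters remains open. An unsubstituted phenyl or an amine at this place would help separate the two.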